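A few compounds are considered here, and "the series" means these few. Any claim that something is new, unique, unknown or untested is made for them only; others in the source may bear on it.

Measured so far:
compound 1 `CCN(C/C=C/C#CC(C)(C)C)Cc1cccc(OCCN(C)S(=O)(=O)c2ccc(C#N)cc2)c1`, 200 nM
compound 2 `CCCN(CCOc1cccc(CN(CC)C/C=C/C#CC(C)(C)C)c1)S(=O)(=O)c1cccs1`, 170 nM
compound 3 `CCN(C/C=C/C#CC(C)(C)C)Cc1cccc(OCCN(C2CC2)S(=O)(=O)c2cccs2)c1`, 230 nM

In a functional assay on HepG2 cells for inhibition of squalene monooxygenase (Homo sapiens) (on this read-out higher numbers stand for weaker inhibition and lower numbers for stronger inhibition), compound 1 stands second highest of the three numbers, with compound 3 nearest and compound 2 furthest, all three within the scatter of one another. Compound 4 `CCN(C/C=C/C#CC(C)(C)C)Cc1cccc(OCCN(C)S(=O)(=O)c2ccc(-c3cccs3)s2)c1` differs from compound 1 in one place: 5-(thiophen-2-yl)thiophen-2-yl in place of 4-cyanophenyl on a sulfonyl sulfur. For the measured compounds named here, the only measured step, a 1.4-fold higher number from compound 2 to compound 3 (0.13 log units; within the scatter), concerns the sulfonamide nitrogen and not the sulfonyl sulfur, so no measured step bears directly on this change. Compounds 2 and 3 show that a thiophen-2-yl on the sulfonyl sulfur gives numbers close to compound 1. The step of a 1.3-fold lower number from compound 1 to compound 4 (0.12 log units; within the scatter) is therefore expected to stay near the scatter. Compound 4 is estimated at 150 nM, between 50 nM and 500 nM.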

Compound 4, half-maximal inhibitory concentration: 10000 nM
Compound 4: the middle estimate sits 67-fold (1.82 log units) below what was measured, outside the stated range (above it).
By their numbers in this assay, from the lowest: compounds 2, 1 and 3 (each within the scatter of the next); then compound 4.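

In this assay, the group on the sulfonyl sulfur proves able to change the number sharply: 5-(thiophen-2-yl)thiophen-2-yl in place of 4-cyanophenyl gives a 50-fold higher number from compound 1 to compound 4 (1.70 log units; beyond the scatter). For the compounds shown here, the only earlier step, a 1.4-fold higher number from compound 2 to compound 3 (0.13 log units; within the scatter), concerned the sulfonamide nitrogen and stayed within the scatter. No measurement at hand explains the size of this new step.

Since the whole group changes at once, the compounds shown cannot say which part of it matters. Also open, from the compounds shown here alone, is how an unsubstituted phenyl or a 4-methoxyphenyl on this sulfur would compare with the 4-cyanophenyl of compound 1.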